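Piperidine nitrogen substituent swap in a cyclohexyl-ether series

The compounds below may be only part of what the source reports. "The series", "measured", "known", "first", "only" and "open" are said of these compounds alone.

Three compounds of the shared core have numbers in a functional assay on isolated protein for agonist activity at Glucose-dependent insulinotropic receptor (Rattus norvegicus), read by HTRF and cAMP accumulation; a higher number here means that more compound is needed for the effect, a lower number that less compound is needed. Compound 1 `CC(C)(C)OC(=O)N1CCC(O[C@H]2CC[C@@H](Oc3ccc(S(C)(=O)=O)cc3)CC2)CC1` gives 1390 nM. Compound 2 `CC(C)OC(=O)N1CCC(O[C@H]2CC[C@H](Oc3ccc(S(C)(=O)=O)nc3)CC2)CC1` gives 201 nM. Compound 3 `CC1(OC(=O)N2CCC(O[C@H]3CC[C@H](Oc4cnc(S(C)(=O)=O)cn4)CC3)CC2)CC1` gives 138 nM; this lies within the scatter of compound 2, while the gap to compound 1 is beyond it.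

Compound 4 `CC(C)c1noc(CN2CCC(O[C@H]3CC[C@H](Oc4cnc(S(C)(=O)=O)cn4)CC3)CC2)n1` is not yet measured. It differs from compound 3 in one place: (3-isopropyl-1,2,4-oxadiazol-5-yl)methyl in place of ((1-methylcyclopropyl)oxy)carbonyl on an amine nitrogen in a ring. For the measured compounds named here, no measured pair shows this change, so its effect is open. The expectation is that compound 4 remains close to compound 3, with at most a modest step in this assay that is estimated as a 1.4-fold lower number from compound 3 to compound 4 (0.14 log units; within the scatter). The estimate for compound 4 is 100 nM, with a range from 25 nM to 500 nM.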

Compound 4, half-maximal effective concentration: 97.9 nM
Beside the measured number, compound 4's estimate is 1.0-fold (0.01 log units) above it, and the stated range covers the measured number.
By their numbers in this assay, from the lowest: compounds 4, 3 and 2 (each within the scatter of the next, the first and the last beyond it); then compound 1.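

In this assay, the step of a 1.4-fold lower number from compound 3 to compound 4 (0.15 log units; within the scatter) is within the scatter, so this amine nitrogen in a ring accepts (3-isopropyl-1,2,4-oxadiazol-5-yl)methyl as well as ((1-methylcyclopropyl)oxy)carbonyl. A group without a carbonyl, joined through a methylene and carrying a five-membered aromatic ring with 3 hetero atoms, therefore serves here. Nothing available explains this outcome.

This single pair leaves open whether the change holds with the other aryl ethers of compound 1 and compound 2. Also open, as far as these compounds go, is how a plain benzyl group or a carboxylic acid on this nitrogen would read.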